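A few compounds are considered here, and "the series" means these few. Any claim that something is new, unique, unknown or untested is made for them only; others in the source may bear on it.

Compound 2 `N#C/C(=C\N1CCN(C(=O)c2ccco2)C1=S)C(N)=O` and compound 1 `N#C/C(=C\N1CCN(C(=O)c2ccco2)C1=S)C(=O)Nc1ccc(Cl)cc1` share a common core and differ only at the amide nitrogen. In a functional assay on EKVX cells (Homo sapiens) for inhibition, read by sulforhodamine B assay, with a stated time of 48 h (on this read-out higher numbers stand for weaker inhibition of growth and lower numbers for stronger inhibition of growth), compound 2 gives 300 nM, the highest of the two numbers recorded, and compound 1 gives 10 nM. Among the compounds with values here, the single measured step, a 30-fold higher number from compound 1 to compound 2 (1.48 log units; beyond the scatter), shows that replacing the 4-chlorophenyl with hydrogen on that nitrogen weakened growth inhibition markedly.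

Compound 3 `N#C/C(=C\N1CCN(C(=O)c2ccco2)C1=S)C(=O)c1ccccc1` is not yet measured. It differs from compound 2 by phenyl in place of amino on a carbonyl carbon, a change at the carbonyl carbon rather than at the nitrogen. Within the data shown here, the only step available bears on it indirectly: it shows that an aromatic ring on the carbonyl-bearing arm of compound 1 goes with a far lower number than the bare carbamoyl of compound 2. Since compound 3 also brings an aromatic ring into that arm, though attached differently, a lower number is expected for compound 3 in this assay, but of smaller size than a 30-fold higher number from compound 1 to compound 2 (1.48 log units; beyond the scatter). Compound 3 is therefore estimated at 100 nM, with a range from 30 nM to 300 nM, which corresponds to a 3.0-fold lower number from compound 2 to compound 3 (0.48 log units; beyond the scatter).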

Compound 3, concentration for 50% growth inhibition: 17800 nM
For compound 3 the middle estimate is 180-fold (2.25 log units) below the measured one, and the stated range ends below it.
By their numbers in this assay, from the lowest: compound 1; then compound 2; then compound 3.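

Putting phenyl in place of amino on the carbonyl carbon gives a 59-fold higher number from compound 2 to compound 3 (1.77 log units; beyond the scatter) in this assay, so an aromatic ring on this carbonyl carbon does not by itself go with stronger inhibition of growth. Putting phenyl in place of (4-chlorophenyl)amino at the same place gives a 1800-fold higher number from compound 1 to compound 3 (3.25 log units; beyond the scatter), and among these three compounds the two that keep a nitrogen on the carbonyl carbon, with or without an aromatic ring on it, have the lower numbers, while the one without that nitrogen has the highest. No measurement is at hand that explains these steps.

The compounds shown leave open what the chlorine adds, since a plain phenylamino group at this place would be needed to separate the chlorine from the ring it sits on, and a methylamino group would show how much a small group on the nitrogen gives. They also leave open whether the nitrogen itself or the amide hydrogen goes with the lower numbers, a question that a dimethylamino group on the same carbonyl carbon would address.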